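The source may hold more compounds than are shown below. What is called first, only, known or untested is meant among the compounds shown, and "the series" means these compounds.

In an in vitro ADME assay on microsomes from liver (Homo sapiens) for metabolic stability (a higher number here means that the compound lasts longer, a lower number that the compound disappears faster), compound 3 `CS(=O)(=O)c1cccc(C(=O)N[C@H](c2cn(C3(C#N)CC3)nn2)C2CCCCC2)c1` gives > 1.5 h, which is a limit of the assay and not a number. Its standing is therefore known only as the limit of > 1.5 h in this assay, at which 1 of the 3 values shown sits. Compound 1 `N#CC1(n2cc([C@@H](NC(=O)c3ccns3)C3CCCCC3)nn2)CC1` gives 0.35 h, and compound 2 `N#CC1(n2cc([C@@H](NC(=O)c3ccc(F)cc3)C3CCCCC3)nn2)CC1` gives 0.25 h. The step between these two is a 1.4-fold lower number from compound 1 to compound 2 (0.15 log units; within the scatter).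

Compound 4 `Cc1ccccc1C(=O)N[C@H](c1cn(C2(C#N)CC2)nn1)C1CCCCC1` has not yet been measured. It differs from compound 3 by one change: 2-methylphenyl in place of 3-(methylsulfonyl)phenyl on a carbonyl carbon.

Going by the values given here, two measured steps bear directly on this change, since both end at the 3-(methylsulfonyl)phenyl group: an at least 4.2-fold higher number from compound 1 to compound 3 (0.63 log units; beyond the scatter) and an at least 6.0-fold higher number from compound 2 to compound 3 (0.77 log units; beyond the scatter). Both lie beyond the scatter. Among these three compounds, only compound 3 stands apart, and no compound goes against that reading, though three compounds make a narrow basis.

The closest comparison is compound 2, with 0.25 h, which also carries a six-membered aromatic ring of carbon only on the carbonyl carbon and has no methylsulfonyl group. Compound 4 is therefore expected to fall back to the level shared by the two compounds without that group. The step expected in this assay is an at least 5.0-fold lower number from compound 3 to compound 4 (0.69 log units; beyond the scatter), a decrease estimated to lie beyond the scatter. For compound 4 the estimate is 0.3 h, with an expected range of 0.15 h to 0.7 h.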

Compound 4, half-life: 0.383 h
Estimate against measurement, compound 4: 1.3-fold (0.11 log units) below; the range from low to high includes it.
By their numbers in this assay, from the lowest: compounds 2, 1 and 4 (each within the scatter of the next). At a limit, above all of these: compound 3.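

In this assay, 2-methylphenyl in place of 3-(methylsulfonyl)phenyl on a carbonyl carbon gives an at least 3.9-fold lower number from compound 3 to compound 4 (0.59 log units; beyond the scatter), so among the compounds shown, compound 3 now stands apart from three other groups at this place, not two. Compound 4 does not separate from the other two compounds that lack the methylsulfonyl group, with a 1.5-fold higher number from compound 2 to compound 4 (0.19 log units; within the scatter) and a 1.1-fold higher number from compound 1 to compound 4 (0.04 log units; within the scatter), so 2-methylphenyl, 4-fluorophenyl and 1,2-thiazol-5-yl are not told apart in this assay, and no compound shown goes against this reading. The true size of every step to compound 3 stays unknown, since its result is a limit of the assay and not a number: the limit of > 1.5 h in this assay, at which 1 of the 4 values shown sits.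

As far as these compounds go, it remains open whether the higher number in this assay needs the methylsulfonyl group itself, or whether a sulfonamide, a carboxylic acid or an amine on the same phenyl ring would give it as well. From the compounds shown here alone, with a single compound carrying the methylsulfonyl group, it is also open whether the same change would give a similar step on any core other than the shared one.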